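Working notes: phenyl to benzyl on the oxygen

The source may hold more compounds than are shown below. What is called first, only, known or untested is meant among the compounds shown, and "the series" means these compounds.

In a functional assay on HT-29 cells (Homo sapiens) for inhibition, read by sulforhodamine B assay, with a stated time of 48 h (on this read-out higher numbers stand for weaker inhibition of growth and lower numbers for stronger inhibition of growth), compound 1 `c1ccc(COc2ccc(NC3=NCCO3)cc2)cc1` gives 10300 nM, compound 2 `O=C(CCl)NC(=O)Nc1ccc(OC2CCCCC2)cc1` gives 3100 nM, and compound 3 `O=C(CCl)NC(=O)Nc1ccc(Oc2ccccc2)cc1` gives 3600 nM. Compound 3 therefore stands within the scatter of compound 2, and its number is lower than that of compound 1, which has a different core. Compound 4 `O=C(CCl)NC(=O)Nc1ccc(OCc2ccccc2)cc1` departs from compound 3 in one place: benzyl in place of phenyl on an oxygen on an aromatic ring. Among the measured compounds shown here, the only measured step at this place, a 1.2-fold higher number from compound 2 to compound 3 (0.06 log units; within the scatter), was small, so no change beyond the scatter is expected in this assay. The expected step is a 1.0-fold lower number from compound 3 to compound 4 (0.01 log units; within the scatter). For compound 4 the estimated value is 3500 nM, with an expected range of 1700 nM to 7500 nM.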

Compound 4, concentration for 50% growth inhibition: 2600 nM
For compound 4 the middle estimate is 1.3-fold (0.13 log units) above the measured one; the range from low to high includes it.
By their numbers in this assay, from the lowest: compounds 4, 2 and 3 (each within the scatter of the next); then compound 1.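

In this assay, benzyl in place of phenyl on the oxygen leaves the number within the scatter (a 1.4-fold lower number from compound 3 to compound 4 (0.14 log units; within the scatter)), as does benzyl in place of cyclohexyl (a 1.2-fold lower number from compound 2 to compound 4 (0.08 log units; within the scatter)), so these three groups at this place read alike. Only the change on the nitrogen on an aromatic ring goes beyond the scatter (a 4.0-fold lower number from compound 1 to compound 4 (0.60 log units; beyond the scatter)). No measurement at hand explains either result.

From the compounds shown here alone, whether an amine or a longer alkyl chain on the oxygen would hold this level stays open. So does the effect of a plain acetyl group in place of the chloroacetyl group.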